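Removing a bromine from a weak, limit-bound triazole compound

The source may report more compounds than this note shows. Statements on the series, on what has been measured and on what is new or still open speak of the compounds shown alone.

Compound 1 `Cc1ccc(S(=O)(=O)Oc2ccc3c(c2C)[C@H](Cn2cc(-c4ccc(Br)cc4)nn2)[C@@]24CC(=O)[C@@](C)(CC[C@@H]32)C4)cc1`: in a functional assay on A549 cells (Homo sapiens) for cytotoxicity, read by MTT assay, with a stated time of 4 days (a higher number here means a weaker inhibitor, a lower number a stronger inhibitor), compound 1 gives > 20000 nM, a limit of the assay rather than a number.
Compound 2 `C=C1C[C@]23C[C@@]1(O)CC[C@H]2c1ccc(O)c(C)c1[C@@H]3Cn1cc(-c2ccc(C)cc2)nn1`: in this assay compound 2 gives > 20000 nM, again a limit and not a number.

Compound 1 therefore stands only at a limit; there is no measured number to place it against. For the measured compounds named here, the same holds for compound 2, and the one piece of evidence on the set is simply (the limit of > 20000 nM in this assay, at which 2 of the 2 values shown sit). Going by the values given here, no step between measured compounds is available, so nothing in the data shows how a single change moves this readout.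

Among the compounds with values here, compound 3 `Cc1ccc(S(=O)(=O)Oc2ccc3c(c2C)[C@H](Cn2cc(-c4ccccc4)nn2)[C@@]24CC(=O)[C@@](C)(CC[C@@H]32)C4)cc1` is the one change from compound 1 described here: hydrogen in place of bromo on an aromatic carbon. With both measured compounds at the same limit, no step beyond the usual scatter is expected in this assay from this change, in either direction. Compound 3 is therefore expected to return a value near the same limit, estimated at 30000 nM with a range from 10000 nM to 100000 nM. The expected step that the limit leaves unreadable from compound 1 to compound 3 is essentially none.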

Compound 3, half-maximal inhibitory concentration: > 20000 nM
Compound 3: a limit, no number; the forecaster's own chance of this, stated with the estimate: 85%; the middle value does not contradict the limit.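

In this assay compound 3 gives > 20000 nM, which is a limit and not a number. For the compounds shown here, compound 1 sits at the same limit, so no step between compound 1 and compound 3 can be read. The compounds shown leave open which structural change, if any, would give a measured number in this assay.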